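Replacing dimethylamino with trifluoromethyl on the aryl ring

The compounds below may be only part of what the source reports. "The series", "measured", "known", "first", "only" and "open" are said of these compounds alone.

Compound 3 `CN(C)c1ccc(C(=O)/C=C/c2ccncc2)cc1` gives 11000 nM in a functional assay with Rattus norvegicus as the target (a higher number here means a weaker inhibitor, a lower number a stronger inhibitor), which is the lowest of the two plain numbers in hand. Within the data shown here, compound 1 `CC(C)(C)c1ccc(C(=O)/C=C/c2ccncc2)cc1` gives 47000 nM in this assay, and the step of a 4.3-fold lower number from compound 1 to compound 3 (0.63 log units; beyond the scatter) is the single measured change at the same aromatic carbon. Compound 2 `COc1cc(C(=O)/C(C)=C/c2ccncc2)cc(OC)c1OC` is reported in this assay only as a limit, > 100000 nM, and not as a number (the limit of > 100000 nM in this assay, at which 1 of the 3 values shown sits). Compound 4 `O=C(/C=C/c1ccncc1)c1ccc(C(F)(F)F)cc1` has not been measured; its difference from compound 3 is trifluoromethyl in place of dimethylamino on an aromatic carbon. Among the measured compounds shown here, the only measured step that bears on this change is the one in which tert-butyl was exchanged for dimethylamino, and there the dimethylamino gave the lower number by a modest but real margin. With the dimethylamino now leaving and a trifluoromethyl entering on the same aromatic carbon, the expectation in this assay is a 4.1-fold higher number from compound 3 to compound 4 (0.61 log units; beyond the scatter), a move beyond the scatter toward a higher number, roughly undoing the earlier gain. Compound 4 is therefore estimated at 45000 nM in this assay, with a range from 15000 nM to 130000 nM, and a real chance that only a limit is returned.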

Compound 4, half-maximal inhibitory concentration: 204000 nM
Compound 4: middle estimate off by 4.5-fold (0.66 log units), on the low side, and the stated range ends below it.
By their numbers in this assay, from the lowest: compound 3; then compound 1; then compound 4.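

Among these compounds, at the aromatic carbon para to a large group, the choice of substituent matters more than the earlier compounds showed: a 19-fold higher number from compound 3 to compound 4 (1.27 log units; beyond the scatter) in this assay is a large step, well beyond the modest 4.3-fold lower number from compound 1 to compound 3 (0.63 log units; beyond the scatter) that was the only change available before. Trifluoromethyl also falls behind tert-butyl, with a 4.3-fold higher number from compound 1 to compound 4 (0.64 log units; beyond the scatter) in the same assay, so the three groups at this one carbon now order as dimethylamino, tert-butyl, trifluoromethyl from the lowest number, each step beyond the scatter. Dimethylamino therefore holds the lowest number of the three compounds that differ only here, but no measured property in hand accounts for this order.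

From the compounds shown here alone, whether the low number stays with other nitrogen groups at this carbon, such as a plain primary amine, a morpholine or a piperidine, or extends to a methoxy group, remains open. Compound 2 stands only as a limit, > 100000 nM, and it differs from the others in more than one place, so it cannot be placed in this order.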